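A few compounds are considered here, and "the series" means these few. Any claim that something is new, unique, unknown or untested is made for them only; others in the source may bear on it.

Compound 2, with the structure `COc1ccc(-c2c(C#N)c(N)n(/N=C/c3cn(-c4ccccc4)nc3-c3ccccc3)c(=O)c2C#N)cc1`, is the starting point of this step. In an ADME assay on HeLa cells (Homo sapiens) for cytotoxicity, read by MTT assay (a higher number here means a weaker inhibitor, a lower number a stronger inhibitor), compound 2 gives > 200 ug/mL, which is a limit of the assay and not a number. Its closest measured relative is compound 1, with the structure `N#Cc1c(-c2ccc(O)cc2)c(C#N)c(=O)n(/N=C/c2cn(-c3ccccc3)nc2-c2ccccc2)c1N`. In this assay compound 1 gives > 200 ug/mL, again a limit rather than a number. The change from compound 1 to compound 2, a methyl in place of hydrogen on an oxygen on an aromatic ring, yields a step that the two limits leave unreadable from compound 1 to compound 2, since both compounds stand at the limit of > 200 ug/mL in this assay, at which 2 of the 2 values shown sit, and the size of that step cannot be read. Compound 3, with the structure `N#Cc1c(-c2ccccc2Br)c(C#N)c(=O)n(/N=C/c2cn(-c3ccccc3)nc2-c2ccccc2)c1N`, arises from compound 2 by a different change: 2-bromophenyl in place of 4-methoxyphenyl on an aromatic carbon. For the measured compounds named here, no measured step covers this swap of one aryl group for another, and the only step that exists between measured compounds is itself unreadable. The expected step from compound 2 to compound 3 is therefore a step that the limit leaves unreadable from compound 2 to compound 3, with no move beyond the scatter foreseen. Compound 3 is expected to give about 250 ug/mL in this assay, in a range from 100 ug/mL to 600 ug/mL, most likely reported once more only as a limit.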

Compound 3, half-maximal inhibitory concentration: > 200 ug/mL
Compound 3: a limit, no number (the forecaster's own chance of this, stated with the estimate: 75%); the middle value is on the limit's open side.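

For the compounds shown here, compound 1, compound 2 and compound 3 all end at a limit and not a number, so no step among them can be read in this assay: the limit of > 200 ug/mL in this assay, at which 3 of the 3 values shown sit. Left open is whether swapping the 4-hydroxyphenyl, 4-methoxyphenyl or 2-bromophenyl group changes the result in this assay at all, and how large any such change would be.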